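The source may report more compounds than this note shows. Statements on the series, on what has been measured and on what is new or still open speak of the compounds shown alone.

For the measured compounds named here, in an ADME assay on the whole organism with Oryza sativa as the target, tested at 10 uM (on this read-out lower numbers stand for a stronger effect and higher numbers for a weaker effect at the one concentration tested), compound 2 `CC(=O)c1ccccc1NC(=O)N[C@H](C)c1ccccc1` gives 89%, the highest of the two numbers measured so far; the only other measured compound, compound 1 `C[C@@H](NC(=O)Nc1ccccc1C(C)(C)C)c1ccccc1`, gives 17%. Compound 3 `C[C@@H](NC(=O)Nc1ccccc1F)c1ccccc1` differs from compound 2 by fluoro in place of acetyl on an aromatic carbon. Going by the values given here, the single measured step, a number 72 percentage points higher from compound 1 to compound 2 (beyond the scatter), exchanged tert-butyl for acetyl at the same spot, so no measured step speaks directly for fluoro there. With that gap in the data, a step of a number 39 percentage points lower from compound 2 to compound 3 (beyond the scatter) toward a stronger effect is expected, with wide uncertainty. Compound 3 is therefore estimated at 50%, between 15% and 90%, in this assay.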

Compound 3, a percentage reported as activity, at one concentration (the size of the read-out at that concentration, not a potency): 77%
Beside the measured number, compound 3's estimate is 27 percentage points below it; the range from low to high includes it.
By their numbers in this assay, from the lowest: compound 1; then compound 3; then compound 2.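

Fluoro in place of acetyl gives a number 12 percentage points lower from compound 2 to compound 3 (beyond the scatter), whereas fluoro in place of tert-butyl gives a number 60 percentage points higher from compound 1 to compound 3 (beyond the scatter). In this assay, the strong effect at this position therefore belongs to tert-butyl alone among the three groups, while fluoro and acetyl both leave a much weaker effect, though not an equal one. Nothing at hand explains this difference. From the compounds shown here alone, it remains open whether an isopropyl or a methoxy group on this aromatic carbon would land close to compound 1 or close to compound 3.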